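Urea to Amide Swap on a Pyrazole Series

This account rests on a few compounds, and the source may have more. Where it says the series, first, only, none or still open, it means among the compounds named here.

Measured compounds:
compound 1, `O=C(Nc1cccc(-n2cc(-c3ccncc3)c(-c3cc(O)cc(Cl)c3)n2)c1)Nc1ccc(Cl)c(Cl)c1`: -27%
compound 2, `COc1cc(Cl)cc(-c2nn(-c3cccc(NC(=O)Nc4cc(C(F)(F)F)cc(C(F)(F)F)c4)c3)cc2-c2ccncc2)c1`: -8%
compound 3, `COc1cc(Cl)cc(-c2nn(-c3cccc(NC(=O)Nc4ccc(Cl)c(Cl)c4)c3)cc2-c2ccncc2)c1`: -34%

In a functional assay on RPMI-8226 cells (Homo sapiens) for inhibition, read by sulforhodamine B assay, with a stated time of 48 h, tested at 100 uM (a higher number here means a weaker effect of the compound at the concentration tested, a lower number a stronger effect), compound 3 gives the lowest of the three numbers. Among the compounds with values here, its nearest neighbour is compound 1, and the only measured step, a number 7 percentage points lower from compound 1 to compound 3 (within the scatter), lies within the scatter. Within the data shown here, compound 2 is further away, and its value stands beyond the scatter from that of compound 3, but no single-point step links those two.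

Compound 4, `COc1cc(Cl)cc(-c2nn(-c3cccc(NC(=O)c4cccc(C(F)(F)F)c4)c3)cc2-c2ccncc2)c1`, is not yet measured. It differs from compound 3 in one place: 3-(trifluoromethyl)phenyl in place of (3,4-dichlorophenyl)amino on a carbonyl carbon. Among the measured compounds shown here, no measured step touches this part of the molecule, so nothing in the data shows how this assay responds to such a change. For the measured compounds named here, the only hint comes from compound 2, where a different aryl group on the same urea gave a number well above that of compound 3. On that basis the number for compound 4 is expected to drift somewhat upward, with the step of a number 19 percentage points higher from compound 3 to compound 4 (beyond the scatter) expected but uncertain. Compound 4 is estimated at -15%, within -45% to 15%.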

Compound 4, a percentage reported as activity, at one concentration (the size of the read-out at that concentration, not a potency): 22%
For compound 4 the middle estimate is 37 percentage points below the measured one; the whole stated range lies below it.
By their numbers in this assay, from the lowest: compounds 3 and 1 (each within the scatter of the next); then compound 2; then compound 4.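

In this assay, the group on the carbonyl carbon turns out to matter a great deal: the change gives a number 56 percentage points higher from compound 3 to compound 4 (beyond the scatter), whereas the change on the aromatic oxygen stayed within the scatter. This single change replaces the urea with an amide, loses the hydrogen-bond donor counted in (3,4-dichlorophenyl)amino and alters the aryl substituents, so the step cannot be assigned to any one of these. No evidence is available that explains the size of this step.

The compounds shown leave open whether the linkage or the aryl group carries the step, since no amide keeps the 3,4-dichlorophenyl group and no urea carries 3-(trifluoromethyl)phenyl. They also leave open how this position would respond to a non-aromatic group on the carbonyl carbon, such as piperidine.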